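Nitro to indol-5-yl on the aryl group: compound 4

A few compounds are considered here, and "the series" means these few. Any claim that something is new, unique, unknown or untested is made for them only; others in the source may bear on it.

Measured so far in an assay on HEK293 cells for inhibition of neurogenic locus notch homolog protein 1 (Homo sapiens), read by a luciferase reporter and resazurin assay, with a stated time of 16 h; on this read-out higher numbers stand for weaker inhibition and lower numbers for stronger inhibition:
compound 1 `CC1=C(C(=O)OC2CCCCC2)C(c2cccc(C#N)c2)C2=C(CC(C)(C)CC2=O)N1` gives 43200 nM.
compound 2 `CC1=C(C(=O)OCC2CCN(C(=O)OC(C)(C)C)CC2)C(c2cccc([N+](=O)[O-])c2)C2=C(CC(C)(C)CC2=O)N1` gives a limit only, > 10000 nM.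
compound 3 `CC1=C(C(=O)OCC2CCN(C(=O)OC(C)(C)C)CC2)C(c2ccc3ccccc3n2)C2=C(CC(C)(C)CC2=O)N1` gives 330 nM.

Compound 2 thus stands at the limit of > 10000 nM in this assay, at which 1 of the 3 values shown sits; no number is known for it. For the measured compounds named here, the one measured step that bears on the new compound is an at least 30-fold lower number from compound 2 to compound 3 (1.48 log units; beyond the scatter), where the whole 3-nitrophenyl was exchanged for a bicyclic heteroaromatic ring. Compound 4 `CC1=C(C(=O)OCC2CCN(C(=O)OC(C)(C)C)CC2)C(c2cccc(-c3ccc4[nH]ccc4c3)c2)C2=C(CC(C)(C)CC2=O)N1` instead keeps the phenyl and changes it by 1H-indol-5-yl in place of nitro on an aromatic carbon. Since the nitro of compound 2 is removed and an aromatic bicycle enters, a lower number is expected, though smaller than the step to compound 3 because compound 2 gives only > 10000 nM as a starting point. The expected step is an at least 4.0-fold lower number from compound 2 to compound 4 (0.60 log units; beyond the scatter); compound 4 is estimated at 2500 nM, within 400 nM to 15000 nM.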

Compound 4, half-maximal inhibitory concentration: 770 nM
Compound 4: the middle estimate sits 3.2-fold (0.51 log units) above what was measured; low and high end bracket the measured number.
By their numbers in this assay, from the lowest: compound 3; then compound 4; then compound 1.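

In this assay, the 3-nitrophenyl need not be replaced as a whole: with the phenyl kept, 1H-indol-5-yl in place of nitro, meta to a large group, gives an at least 12-fold lower number from compound 2 to compound 4 (1.11 log units; beyond the scatter). The value for compound 2 is a limit, so the full size of this step stays unknown because the starting point is only this: the limit of > 10000 nM in this assay, at which 1 of the 4 values shown sits.

Open, going by these compounds, is whether the aromatic bicycle is needed on this carbon, which a plain phenyl, an amine or a carboxylic acid in the same place would test. Also open, on these data alone, is whether the indole hydrogen on nitrogen contributes, which an N-methylindol-5-yl would address.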